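Cyclising the alkyne substituent: compound 2 to compound 3

This account rests on a few compounds, and the source may have more. Where it says the series, first, only, none or still open, it means among the compounds named here.

Among the compounds with values here, compound 2 `COc1cc[nH]c1/C=C1\C(=O)Nc2ccc(F)c(C#C[C@H](N)CO)c21` is the only member of the series with a number in a functional assay on MDA-MB-435 cells (Homo sapiens) for inhibition (on this read-out lower numbers stand for stronger inhibition and higher numbers for weaker inhibition), where compound 2 gives 320 nM. Compound 1 `COc1cc[nH]c1/C=C1\C(=O)Nc2ccc(F)c(I)c21` sits at a limit of this assay, giving > 30000 nM. The entry the limit of > 30000 nM in this assay, at which 1 of the 2 values shown sits, is a limit and not a number. Within the data shown here, the single measured step is an at least 93-fold lower number from compound 1 to compound 2 (1.97 log units; beyond the scatter), and it shows that the substituent on the aromatic carbon is where the numbers move. Compound 3 `COc1cc[nH]c1/C=C1\C(=O)Nc2ccc(F)c(C#C[C@@H]3C[C@@H](O)CN3)c21` carries the change (4-hydroxypyrrolidin-2-yl in place of 1-amino-2-hydroxyethyl on a triple-bonded carbon). Among the measured compounds shown here, no measured step touches the group on the triple-bonded carbon, so the step from compound 1 to compound 2 bears on it only indirectly. Hydrogen-bond donors and acceptors are unchanged in kind and the ring adds little bulk, so compound 3 is expected to stay close to compound 2, with a 1.1-fold lower number from compound 2 to compound 3 (0.03 log units; within the scatter) within the scatter or only slightly beyond it. Compound 3 is estimated at 300 nM, between 100 nM and 1000 nM.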

Compound 3, half-maximal inhibitory concentration: 63 nM
Compound 3: the middle estimate sits 4.8-fold (0.68 log units) above what was measured; measured number below the stated range.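

In this assay there is a 5.1-fold lower number from compound 2 to compound 3 (0.71 log units; beyond the scatter), with 4-hydroxypyrrolidin-2-yl in place of 1-amino-2-hydroxyethyl, so the numbers move with the group on the triple-bonded carbon and not only with replacing iodo on the aromatic carbon. This shift comes with the counts of hydrogen-bond donors and acceptors unchanged, while a five-membered non-aromatic ring and a second defined stereocentre enter; measured against iodo, the series now reaches an at least 470-fold lower number from compound 1 to compound 3 (2.67 log units; beyond the scatter). The entry for compound 1 is a limit and not a number: the limit of > 30000 nM in this assay, at which 1 of the 3 values shown sits.

As far as these compounds go, whether the shift follows the ring, the hydroxyl or the stereocentres stays open. Also open, from the compounds shown here alone, is how a pyrrolidin-2-yl group without the hydroxyl, or a six-membered piperidin-2-yl ring, would read in this assay.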